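From thiophen-2-yl to furan-2-yl on a growth inhibitor

The compounds below may be only part of what the source reports. "The series", "measured", "known", "first", "only" and "open" are said of these compounds alone.

For the measured compounds named here, in a functional assay on COLO 205 cells (Homo sapiens) for inhibition, read by sulforhodamine B assay, with a stated time of 48 h, tested at 50 uM (on this read-out higher numbers stand for more inhibition of growth at the one concentration tested and lower numbers for less inhibition of growth), compound 1 `COc1cc(/C=C/C(=O)/C=C/c2cccs2)ccc1OCc1cn(CCOc2cc(=O)oc3ccccc23)nn1` gives 66% and stands highest of the two numbers so far, while compound 2 `COc1ccccc1/C=C/C(=O)/C=C/c1ccc(OCc2cn(CCCCOc3cc(=O)oc4ccccc34)nn2)c(OC)c1` gives 47% in a gap beyond the usual scatter. Compound 3 `COc1cc(/C=C/C(=O)/C=C/c2ccco2)ccc1OCc1cn(CCOc2cc(=O)oc3ccccc23)nn1` differs from compound 1 in one place, with furan-2-yl in place of thiophen-2-yl on a double-bonded chain carbon bound to a double-bonded chain carbon. Going by the values given here, no measured pair shows this swap. In this assay the expected outcome is a number 6 percentage points lower from compound 1 to compound 3 (within the scatter) and nothing beyond the scatter. The estimate for compound 3 is 60% (range 45% to 75%).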

Compound 3, percent growth inhibition at one concentration: 68%
For compound 3 the middle estimate is 8 percentage points below the measured one; measured number inside the range.
By their numbers in this assay, from the lowest: compound 2; then compounds 1 and 3 (each within the scatter of the next).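

In this assay, for the compounds shown here, furan-2-yl in place of thiophen-2-yl on a double-bonded chain carbon bound to a double-bonded chain carbon gives a number 2 percentage points higher from compound 1 to compound 3 (within the scatter), the first pair that isolates this position. On this read-out the two rings cannot be told apart, so this position accepts oxygen as the ring hetero atom as well as sulfur. Nothing at hand gives a reason for this. The compounds shown leave open whether a pyridin-2-yl ring or a ring carrying an amine at this place would read alike. They also leave open whether the two rings would still match in another cell line.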